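Two Limits and a Methylpiperazine Amide

The source may hold more compounds than are shown below. What is called first, only, known or untested is meant among the compounds shown, and "the series" means these compounds.

Compound 1 `CC(=O)N1CCN(C(=O)N2Cc3c(NC(=O)c4ccc(F)cc4)n[nH]c3C2(C)C)CC1` and compound 2 `CCN1CCC(C(=O)N2Cc3c(NC(=O)c4ccc(F)cc4)n[nH]c3C2(C)C)CC1` share one core and differ only in the group carried on the carbonyl carbon. In a physicochemical assay for solubility, at pH 7 (on this read-out lower numbers stand for lower solubility and higher numbers for higher solubility), compound 1 gives > 225000 nM, a limit of the assay rather than a number. In this assay compound 2 likewise gives > 225000 nM, again a limit. Both values sit at the limit of > 225000 nM in this assay, at which 2 of the 2 values shown sit, so the step that the two limits leave unreadable from compound 1 to compound 2 cannot be read in size or direction. Compound 3 `CN1CCN(C(=O)N2Cc3c(NC(=O)c4ccc(F)cc4)n[nH]c3C2(C)C)CC1` differs from compound 2 in one place: 4-methylpiperazin-1-yl in place of 1-ethylpiperidin-4-yl on a carbonyl carbon. No readable step bears on this change; what the data show is that compound 2 already stands at the limit of this assay. Compound 3 is therefore expected to stand at that limit as well, with an estimate of 300000 nM and a range from 150000 nM to 600000 nM. The expected step that the limit leaves unreadable from compound 2 to compound 3 is within the scatter.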

Compound 3, solubility: > 225000 nM
Compound 3 was reported as a limit (the forecaster's own chance of this, stated with the estimate: 85%); the middle value lies beyond the limit too.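

In this assay compound 3 gives > 225000 nM, again a limit. The steps among compound 1, compound 2 and compound 3 therefore cannot be read in size or direction: the limit of > 225000 nM in this assay, at which 3 of the 3 values shown sit. The compounds shown leave open how far their true solubilities lie beyond that limit, and whether they differ at all.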